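The source may hold more compounds than are shown below. What is called first, only, known or untested is meant among the compounds shown, and "the series" means these compounds.

The measured compounds:

Compound 1, `CO[C@H]1C(=O)N2C(C(=O)C(C)(C)C)=C(CSc3nnnn3C)CS(=O)(=O)C12`, in a physicochemical assay, at pH 7.4 (a higher number here means that the compound lasts longer, a lower number that the compound disappears faster), gives 24 h.
Compound 2, `CO[C@H]1C(=O)N2C(C(=O)c3ccccc3)=C(CSc3nnnn3C)CS(=O)(=O)C12`, in this assay gives 17 h.
Compound 3, `CO[C@H]1C(=O)N2C(C(=O)C(C)(C)C)=C(C)[C@@H](Sc3nnnn3C)S(=O)(=O)C12`, in this assay gives 18 h.

Compound 1 and compound 2 share a core and differ in one place only: phenyl in place of tert-butyl on a carbonyl carbon. That change produced a step of a 1.4-fold lower number from compound 1 to compound 2 (0.15 log units; within the scatter), so the two half-lives sit within the usual scatter of each other.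

Compound 3 has the same atoms as compound 1 joined differently; the difference between the two cores is not broken down here. Compound 4, `CO[C@H]1C(=O)N2C(C(=O)c3ccccc3)=C(C)[C@@H](Sc3nnnn3C)S(=O)(=O)C12`, stands to compound 3 as compound 2 stands to compound 1: phenyl in place of tert-butyl on a carbonyl carbon. The place line around the carbonyl carbon reads the same for both pairs, so this is the same change, made a second time on the other core. Among the compounds shown it occurs in these two pairs and nowhere else.

For the measured compounds named here, since the only measured instance of this change, from compound 1 to compound 2, gave a 1.4-fold lower number from compound 1 to compound 2 (0.15 log units; within the scatter), compound 4 is expected to lie close to compound 3, with an estimated step of a 1.3-fold lower number from compound 3 to compound 4 (0.11 log units; within the scatter). Compound 4 is therefore estimated at 14 h in this assay, with a likely range from 8 h to 25 h; this rests on a single earlier step on a different core, so the range is kept wide.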

Compound 4, half-life: 200 h
Compound 4: the middle estimate sits 14-fold (1.15 log units) below what was measured; measured number above the stated range.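

Putting phenyl in place of tert-butyl on a carbonyl carbon did not give the same result on the two cores: in this assay the change gave a step of a 1.4-fold lower number from compound 1 to compound 2 (0.15 log units; within the scatter) on the core of compound 1, but a step of an 11-fold higher number from compound 3 to compound 4 (1.05 log units; beyond the scatter) on the core of compound 3. This shows that in this series a step read on one core cannot simply be carried over to the other, since the same change stays within the scatter in one pair and lies far beyond it in the other, although with one pair per core it gives no rule for any further core. It does not show what sets the two cores apart, and nothing available bears on the cause of the large step.

The compounds shown leave open whether the large step on the core of compound 3 belongs to phenyl itself or would also appear with another group on that carbonyl carbon, such as cyclohexyl or pyridyl. They also leave open how a carboxylic acid or an amine carried on the phenyl ring would fare on each of the two cores.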